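Replacing a tetrazole with a thiazole on the sulfur

The source may hold more compounds than are shown below. What is called first, only, known or untested is meant among the compounds shown, and "the series" means these compounds.

Within the data shown here, compound 1 `C#CCSc1nc(Sc2nnnn2CCN(C)C)c(C#N)c(-c2ccc(Cl)cc2)n1` is one of two compounds measured in a functional assay on KYSE-70 cells for antiproliferative activity against KYSE-70 cell line (Homo sapiens), read by MTT assay, with a stated time of 72 h; on this read-out lower numbers stand for stronger inhibition and higher numbers for weaker inhibition. In this assay compound 1 gives 6560 nM, and compound 2 `C#CCSc1nc(Sc2nncs2)c(C#N)c(-c2cc(OC)c(OC)c(OC)c2)n1` gives 8250 nM; the gap between the two lies within the usual scatter, so neither stands apart from the other. Compound 3 `C#CCSc1nc(Sc2nccs2)c(C#N)c(-c2ccc(Cl)cc2)n1` differs from compound 1 in one place: 1,3-thiazol-2-yl in place of 1-(2-(dimethylamino)ethyl)-1H-tetrazol-5-yl on a sulfur. Among the measured compounds shown here, no measured pair shows what this swap does, so a small step, if any, is expected in this assay. Compound 3 is estimated at 8000 nM, with a range from 3000 nM to 20000 nM. This expectation amounts to a step from compound 1 to compound 3 of a 1.2-fold higher number from compound 1 to compound 3 (0.09 log units; within the scatter).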

Compound 3, half-maximal inhibitory concentration: 5350 nM
The estimate for compound 3 lay 1.5-fold (0.17 log units) above the measured number; measured number inside the range.
By their numbers in this assay, from the lowest: compounds 3, 1 and 2 (each within the scatter of the next).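

Among these compounds, this step is the first direct comparison at this sulfur: a 1.2-fold lower number from compound 1 to compound 3 (0.09 log units; within the scatter) in this assay. The 1-(2-(dimethylamino)ethyl)-1H-tetrazol-5-yl group, with its chain, and the 1,3-thiazol-2-yl group, with fewer heavy atoms, therefore cannot be told apart on this read-out. No supporting data bear on why the two groups read alike. On these data alone, what a methyl group or a carboxylic acid would do on this sulfur stays open, as does whether the same swap reads alike on a different core.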